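Aryl variation on the ring amine: adenosine binding notes

The source may hold more compounds than are shown below. What is called first, only, known or untested is meant among the compounds shown, and "the series" means these compounds.

Measured compounds:
compound 1, `Nc1scc(CN2CCN(c3ccc(Cl)cc3Cl)CC2)c1C(=O)c1ccc(Cl)cc1`: 0%
compound 2, `Nc1scc(CN2CCN(c3cccc4ccccc34)CC2)c1C(=O)c1ccc(Cl)cc1`: 1%

In an assay on CHO cells for displacement of a labelled ligand from adenosine receptor A1 (Homo sapiens), read by scintillation counting, with a stated time of 120 min, tested at 10 uM (a lower number here means less inhibition, a higher number more inhibition at the concentration tested (going by the name of the read-out)), compound 1 gives 0% and compound 2 gives 1%. Among the measured compounds shown here, both numbers sit at the floor of the read-out; the only measured step, a number 1 percentage points higher from compound 1 to compound 2 (within the scatter), lies within the scatter, so compound 2 cannot be set apart from compound 1 on these values.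

Compound 3, `Nc1scc(CN2CCN(c3c(F)cccc3F)CC2)c1C(=O)c1ccc(Cl)cc1`, differs from compound 2 by 2,6-difluorophenyl in place of naphthalen-1-yl on an amine nitrogen in a ring. For the measured compounds named here, the one step that bears on this is the exchange of the group on the same ring nitrogen, a number 1 percentage points higher from compound 1 to compound 2 (within the scatter), which changed nothing beyond the scatter. With two different aryl groups on that nitrogen both giving essentially no inhibition, no step beyond the scatter is expected in this assay for a third one, a number 1 percentage points higher from compound 2 to compound 3 (within the scatter). Compound 3 is therefore estimated at 2%, within -8% to 12%.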

Compound 3, a percentage reported as inhibition, at one concentration (the size of the read-out at that concentration, not a potency): 1%
Estimate against measurement, compound 3: 1 percentage points above, and the stated range covers the measured number.
By their numbers in this assay, from the lowest: compounds 1, 2 and 3 (each within the scatter of the next).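

In this assay, the step to 2,6-difluorophenyl shows no change at the digits printed from compound 2 to compound 3 (within the scatter), and the comparison with the 2,4-dichlorophenyl compound shows a number 1 percentage points higher from compound 1 to compound 3 (within the scatter). On an amine nitrogen in a ring, a single fluorinated aromatic ring therefore reads the same as naphthalen-1-yl, with its two six-membered aromatic rings, and as a chlorinated one, so neither the ring count nor the choice of halogen among these three groups separates the compounds. Nothing measured alongside these numbers offers an explanation for this flat result.

Still open, on these data alone, is whether a group other than a directly attached aromatic ring on that nitrogen, such as a benzyl group or a longer alkyl chain, would give a different reading. Also open, as far as these compounds go, is whether changing the shared core, for instance an amide in place of its free amine, would do so.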